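This account rests on a few compounds, and the source may have more. Where it says the series, first, only, none or still open, it means among the compounds named here.

This piece follows a single structural change and asks what it may do to the toxicity of a compound toward a human monocyte-like cell line. The read-out is a toxicity assay on THP-1 cells (Homo sapiens) for inhibition; on this read-out lower numbers stand for higher toxicity in this test and higher numbers for lower toxicity in this test. Of the compounds shown here, three have been measured so far, and none of them gave a number. Compound 1 `Cn1c(-c2cccc([N+](=O)[O-])c2)cnc1NC(=O)c1ccc(F)cc1` reaches only a limit of the test, > 50000 nM. Compound 2 `COc1ccc(CNC(=O)NC(=O)c2ccc(F)cc2)cc1` likewise stops at a limit, > 50000 nM. Compound 3 `COc1ccc(-c2cnc(NC(=O)c3ccn[nH]3)n2C)cc1` also stands at a limit, > 100000 nM, and this is the highest concentration reached by any of the three. Two lines sum up where the measured values sit: the limit of > 100000 nM in this assay, at which 1 of the 3 values shown sits, and (the limit of > 50000 nM in this assay, at which 2 of the 3 values shown sit). For the measured compounds named here, because all three are limits, no step between measured compounds can be given a size.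

Compound 4 `COc1ccc(-c2cnc(NC(=O)c3ccc(O)cc3)n2C)cc1` has not yet been measured. It differs from compound 3 by one change on the carbonyl carbon: 4-hydroxyphenyl in place of 1H-pyrazol-5-yl on a carbonyl carbon. With compound 3 showing no measurable toxicity, its result > 100000 nM being a limit, the step from compound 3 to compound 4 is expected to be a number no higher from compound 3 to compound 4 (the limit leaves the size open), meaning no change beyond the scatter. Compound 4 is therefore expected to give 100000 nM, somewhere between 40000 nM and 300000 nM, and most likely the test will again return only a limit.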

Compound 4, half-maximal cytotoxic concentration: > 100000 nM
Compound 4: a limit, no number; the forecaster's own chance of this, stated with the estimate: 85%; the middle value lies on the limit itself.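

For the compounds shown here, compound 3 and compound 4 both end at a limit of the test rather than at a number, so no step between them can be read. The compounds shown leave open whether 4-hydroxyphenyl in place of 1H-pyrazol-5-yl on a carbonyl carbon changes the result in this assay at all, and what number either compound would give.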